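Fluoro on the saturated ring of compound 2

The source may report more compounds than this note shows. Statements on the series, on what has been measured and on what is new or still open speak of the compounds shown alone.

Compound 2 `O=C(Nc1ccnnc1)c1cc(N2CCCCC2)ccc1OCc1ccccc1` is the parent of the step considered here. Among the measured compounds shown here, in an assay on Sf9 cells for inhibition of Leucine-rich repeat serine/threonine-protein kinase 2 (Homo sapiens), read by TR-FRET, with stated times of 30 min and 2 h (a lower number here means a stronger inhibitor, a higher number a weaker inhibitor), compound 2 gives 25.1 nM, the second highest of the three numbers known so far. Compound 3 `O=C(Nc1cccc(Cl)c1)c1cc(C(F)(F)F)ccc1OCc1ccc(F)cc1` gives 12.6 nM, and compound 1 `O=C(Nc1ccnnc1)c1cc(N2C[C@H]3COC[C@H]3C2)ccc1OCc1ccccc1` gives 50.1 nM; the gaps from compound 2 to each of these lie within the scatter, so no order among the three can be read from them.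

For the measured compounds named here, the only measured step with a single point of difference is a 2.0-fold lower number from compound 1 to compound 2 (0.30 log units; within the scatter), an exchange of the saturated ring on the aromatic carbon.

Compound 4 `O=C(Nc1ccnnc1)c1cc(N2CCC(F)CC2)ccc1OCc1ccccc1` is not yet measured. It differs from compound 2 by fluoro in place of hydrogen on a saturated ring carbon. Going by the values given here, no measured step bears directly on a substituent placed on the saturated ring: the step from compound 1 to compound 2 exchanges the whole ring rather than adding to it, and compound 3 differs from compound 2 in more than one place. What can be said is that the ring exchange itself stayed within the scatter, which gives no ground to expect a step beyond the scatter in this assay in either direction. The expected step is therefore a 1.0-fold lower number from compound 2 to compound 4 (0.00 log units; within the scatter). Compound 4 is estimated at 25 nM, with a range from 10 nM to 63 nM.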

Compound 4, half-maximal inhibitory concentration: 39.8 nM
The estimate for compound 4 lay 1.6-fold (0.20 log units) below the measured number; the measured number falls inside the stated range.
By their numbers in this assay, from the lowest: compounds 3, 2, 4 and 1 (each within the scatter of the next, the first and the last beyond it).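

Among the compounds shown here, compound 4 gives the first reading of a substituent on the saturated ring itself, rather than an exchange of the whole ring. In this assay, placing fluoro on the ring carbon three ring bonds from the ring nitrogen, which turns piperidin-1-yl into 4-fluoropiperidin-1-yl, gives a step within the scatter (a 1.6-fold higher number from compound 2 to compound 4 (0.20 log units; within the scatter)), so no order can be read between these two compounds. The comparison with the group carried by compound 1 also stays within the scatter (a 1.3-fold lower number from compound 1 to compound 4 (0.10 log units; within the scatter)), so compound 1, compound 2 and compound 4 show that this aromatic carbon accepts these saturated groups with no listed step among them beyond the scatter, and no measurement is on hand to account for this.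

Going by these compounds, a single small atom at one ring carbon says little about that carbon in general, and it stays open whether a hydroxyl, an amine or a carboxylic acid there would give a step beyond the scatter. Also open, on these data alone, is how a second fluoro on the same carbon, or a morpholin-4-yl or pyrrolidin-1-yl ring in place of the piperidine, would read in this assay.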